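Working notes: toxicity limits and the step to compound 4

The compounds below may be only part of what the source reports. "The series", "measured", "known", "first", "only" and "open" are said of these compounds alone.

Measured so far in this series:
compound 1 `COc1cccc(-c2cnc(NC(=O)c3ccc(F)cc3)n2C)c1` gives > 100000 nM
compound 2 `Cn1c(-c2ccc(C#N)cc2)cnc1NC(=O)c1ccc(F)cc1` gives > 50000 nM
compound 3 `Cn1c(-c2ccc([N+](=O)[O-])cc2)cnc1NC(=O)c1ccc(F)cc1` gives > 50000 nM

Among the compounds with values here, every value so far in a toxicity assay on THP-1 cells (Homo sapiens) for inhibition (on this read-out higher numbers stand for lower toxicity in this test and lower numbers for higher toxicity in this test), is a limit of the assay and not a number. Compound 1 sits at the limit of > 100000 nM in this assay, at which 1 of the 3 values shown sits. Compound 2 sits at the limit of > 50000 nM in this assay, at which 2 of the 3 values shown sit. Compound 3 sits at that same limit. Compound 2 therefore stands only at a limit, and the two further values shown are limits as well, so no order among the three can be read. Accordingly the step that the two limits leave unreadable from compound 1 to compound 2 has no readable size, and the step that the two limits leave unreadable from compound 2 to compound 3 has none either.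

The next compound is compound 4 `COc1ccccc1-c1cnc(NC(=O)c2ccc(F)cc2)n1C`. It differs from compound 2 by the change (2-methoxyphenyl in place of 4-cyanophenyl on an aromatic carbon).

The two measured steps that touch compound 2 are the only ones that bear on this change, and both leave their size unreadable between limits. No step beyond the scatter in this assay can be read from them, in either direction; what they do show is that three different groups in the same place all stay at the limit. Compound 4 is expected to behave the same way, and its step that the limit leaves unreadable from compound 2 to compound 4 is estimated to be no change beyond the scatter. Compound 4 is thus expected to give about 100000 nM, between 30000 nM and 300000 nM, most likely reported again only as a limit.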

Compound 4, half-maximal cytotoxic concentration: > 100000 nM
Compound 4 was reported as a limit; the forecaster's own chance of this, stated with the estimate: 85%; the middle value lies on the limit itself.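

In this assay compound 4 gives > 100000 nM, which is a limit and not a number. Compound 2 gives > 50000 nM, also a limit. Compound 1 gives > 100000 nM, again a limit. Within the data shown here, no step from compound 1 or compound 2 to compound 4 can be read. The compounds shown leave open how these compounds order in toxicity, and whether any group in this place gives a measured number.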